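The compounds below may be only part of what the source reports. "The series", "measured", "known", "first", "only" and "open" are said of these compounds alone.

Compound 1 `CN(C(=O)NC(=O)c1ccc(F)c(F)c1)c1nc(C(F)(F)F)c(C(=O)N/N=C/c2ccc(C(F)(F)F)cc2)s1` gives 3.85 ug/mL in a functional assay on BCG823 cells (Homo sapiens) for inhibition, read by MTT assay, with a stated time of 72 h; on this read-out lower numbers stand for stronger inhibition and higher numbers for weaker inhibition. Compound 3 `CN(C(=O)NC(=O)c1ccc(C(F)(F)F)cc1)c1nc(C(F)(F)F)c(C(=O)N/N=C/c2cccc(C(F)(F)F)c2)s1` gives 1.84 ug/mL in this assay. Compound 2 `CN(C(=O)NC(=O)c1ccc(C(F)(F)F)cc1)c1nc(C(F)(F)F)c(C(=O)N/N=C/c2ccc(C(F)(F)F)cc2)s1` reaches only a limit, > 100 ug/mL, in this assay, and so sits at the limit of > 100 ug/mL in this assay, at which 1 of the 3 values shown sits.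

The change 3,4-difluorophenyl in place of 4-(trifluoromethyl)phenyl on a carbonyl carbon gave an at least 25-fold lower number from compound 2 to compound 1 (1.41 log units; beyond the scatter). The two cores differ by 3-(trifluoromethyl)phenyl in place of 4-(trifluoromethyl)phenyl on a carbon with a double bond to nitrogen, which gave an at least 54-fold lower number from compound 2 to compound 3 (1.73 log units; beyond the scatter). Compound 4 `CN(C(=O)NC(=O)c1ccc(F)c(F)c1)c1nc(C(F)(F)F)c(C(=O)N/N=C/c2cccc(C(F)(F)F)c2)s1` carries the same change on the core of compound 3: 3,4-difluorophenyl in place of 4-(trifluoromethyl)phenyl on a carbonyl carbon, with the place described in the same words as for compound 1. On these data alone, because the earlier step of an at least 25-fold lower number from compound 2 to compound 1 (1.41 log units; beyond the scatter) starts from a limit, its true size is unknown, and compound 3 already stands low; the step of a 1.8-fold lower number from compound 3 to compound 4 (0.26 log units; within the scatter) is expected to be smaller than the earlier one. Compound 4 is estimated at 1 ug/mL, with a likely range from 0.3 ug/mL to 4 ug/mL.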

Compound 4, half-maximal inhibitory concentration: 4.46 ug/mL
Estimate against measurement, compound 4: 4.5-fold (0.65 log units) below; measured number above the stated range.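

The change to 3,4-difluorophenyl on a carbonyl carbon does not carry from one core to the other in this assay; on the core of compound 3 it gives a 2.4-fold higher number from compound 3 to compound 4 (0.38 log units; beyond the scatter), which sets it apart from the earlier step: the same change on two cores in this assay, an at least 25-fold lower number (1.41 log units; beyond the scatter) from compound 2 to compound 1 and a 2.4-fold higher number (0.38 log units; beyond the scatter) from compound 3 to compound 4, at least 62-fold (1.79 log units) apart, beyond the scatter of two such steps

The change to 3-(trifluoromethyl)phenyl does not carry either, giving a 1.2-fold higher number from compound 1 to compound 4 (0.06 log units; within the scatter), which sets it apart from its earlier step: the same change on two cores in this assay, an at least 54-fold lower number (1.73 log units; beyond the scatter) from compound 2 to compound 3 and a 1.2-fold higher number (0.06 log units; within the scatter) from compound 1 to compound 4, at least 62-fold (1.79 log units) apart, beyond the scatter of two such steps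

Both comparisons rest on compound 2, whose > 100 ug/mL is a limit; they show dependence on the core within these four compounds only, and neither the true size of the gap nor its cause.

Open, on these data alone, is how a phenyl carrying a carboxylic acid or an amine in place of trifluoromethyl would behave on either side of the shared core, and whether compound 2 stays a lone exception among such pairs.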